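The source may report more compounds than this note shows. Statements on the series, on what has been measured and on what is new or still open speak of the compounds shown alone.

Compound 1 `CCOc1cc(-c2ccccc2)nc2ccccc12`: 6.7 ug/mL
Compound 2 `Oc1ccc2nc(-c3ccccc3)cc(O)c2c1`: 0.41 ug/mL

Both compounds were tested in a functional assay on KB cells (Homo sapiens) for cytotoxicity; a lower number here means that less compound is needed, a higher number that more compound is needed for the effect. Compound 2 at 0.41 ug/mL holds the lower of the two numbers, while compound 1 at 6.7 ug/mL lies well above it, beyond the scatter. The next compound, compound 3 `Oc1cc(-c2ccccc2)nc2ccc(Cl)cc12`, has not yet been measured. It departs from compound 2 by a single exchange, (chloro in place of hydroxy on an aromatic carbon), with chloro in place of hydroxy on an aromatic carbon. Going by the values given here, no measured pair isolates this exchange, and the two compounds in hand differ in more than one place, so the data give no direct size for it. Among the compounds with values here, compound 2 at 0.41 ug/mL has the lowest number so far, and a rise in this assay therefore seems the likelier direction, with a moderate size beyond the scatter expected. The expected step, a 6.1-fold higher number from compound 2 to compound 3 (0.79 log units; beyond the scatter), would place the new number between those of the two measured compounds. For compound 3 the estimated value is 2.5 ug/mL, with an expected range from 0.5 ug/mL to 12 ug/mL in this test.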

Compound 3, half-maximal effective concentration: 0.49 ug/mL
Estimate against measurement, compound 3: 5.1-fold (0.71 log units) above, and the stated range ends above it.
By their numbers in this assay, from the lowest: compounds 2 and 3 (each within the scatter of the next); then compound 1.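

In this assay, chloro in place of hydroxy on an aromatic carbon gives a 1.2-fold higher number from compound 2 to compound 3 (0.08 log units; within the scatter), the first measured size for this exchange at this position of the shared core. The position on the six-membered aromatic ring of carbon only, meta to a fused ring and para to a fused ring, therefore accepts chloro, with 0 hydrogen-bond donors and 0 hydrogen-bond acceptors, in place of hydroxy, with 1 hydrogen-bond donor and 1 hydrogen-bond acceptor, with no difference that this test can separate from the scatter. No measurement in hand speaks to why the two numbers lie so close together.

From the compounds shown here alone, it remains open whether other groups at this position, such as an amine, a methoxy group, a carboxylic acid or a longer chain, would also stay within the scatter of compound 2 or would move the number away from it. Compound 2 and compound 3 each differ from compound 1 in more than one place, so the higher number shown by compound 1 at 6.7 ug/mL cannot be assigned to any single change, and what sets it apart remains unresolved.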